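Benzylsulfanyl variation in a sulfonyl-guanidine cytotoxicity series

This account rests on a few compounds, and the source may have more. Where it says the series, first, only, none or still open, it means among the compounds named here.

Compound 1 `Cc1cc(S(=O)(=O)/N=C(\N)n2nccc2-c2ccccc2)c(SCc2cccc(Cl)c2)cc1Cl`: 7000 nM
Compound 2 `Cc1cc(-c2ccccc2)n(/C(N)=N/S(=O)(=O)c2cc(C)c(Cl)cc2SCc2cccc(C(F)(F)F)c2)n1`: 19000 nM

In a functional assay on HCT-116 cells (Homo sapiens) for cytotoxicity, read by MTT assay, with a stated time of 72 h (on this read-out lower numbers stand for stronger inhibition and higher numbers for weaker inhibition), compound 1 gives 7000 nM, the lowest of the two numbers. For the measured compounds named here, compound 2 gives 19000 nM in this assay; no single step links compound 1 and compound 2, and the two values simply stand as they are.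

Compound 3 `Cc1cc(S(=O)(=O)/N=C(\N)n2nccc2-c2ccccc2)c(SCc2ccc(C(F)(F)F)cc2)cc1Cl` differs from compound 1 by 4-(trifluoromethyl)phenyl in place of 3-chlorophenyl on a saturated chain carbon bound to a sulfur. Going by the values given here, the benzyl substituent pattern is otherwise unchanged, and nothing among the measured compounds isolates this change. For the step from compound 1 to compound 3 a change of a 1.3-fold higher number from compound 1 to compound 3 (0.11 log units; within the scatter) is expected, not beyond the usual scatter. Compound 3 is estimated at 9000 nM, between 3500 nM and 25000 nM.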

Compound 3, half-maximal inhibitory concentration: 14000 nM
For compound 3 the middle estimate is 1.6-fold (0.19 log units) below the measured one; measured number inside the range.
By their numbers in this assay, from the lowest: compounds 1, 3 and 2 (each within the scatter of the next, the first and the last beyond it).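

In this assay, for the compounds shown here, the exchange of 3-chlorophenyl for 4-(trifluoromethyl)phenyl on a saturated chain carbon bound to a sulfur gives a 2.0-fold higher number from compound 1 to compound 3 (0.30 log units; within the scatter) and is the first single-place step read. Compound 1 and compound 3 are therefore not separated by this assay, even with the larger group entering at this place. No measurement on hand bears on the reason for this result.

Open, from the compounds shown here alone, is whether an amine, a carboxylic acid or a longer chain at this place would give a step beyond the scatter. A single step also cannot show how far this result extends to other benzyl groups.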